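The source may report more compounds than this note shows. Statements on the series, on what has been measured and on what is new or still open speak of the compounds shown alone.

Compound 1 (`O=C(Nc1cccnc1)c1ccccc1OCc1cccc(Cl)c1`): in an assay on lysate for inhibition of phosphatidylcholine:ceramide cholinephosphotransferase 2 (Homo sapiens), read by HPLC, with stated times of 30 min and 2 h (a lower number here means a stronger inhibitor, a higher number a weaker inhibitor), compound 1 gives 1400 nM.
Compound 2 (`O=C(Nc1cccnc1)c1ccccc1OCc1cc(F)ccc1Cl`): compound 2 gives 740 nM.
Compound 3 (`O=C(Nc1cccnc1)c1ccccc1OCc1c(F)cccc1Cl`): compound 3 gives 1500 nM.

Within the data shown here, compound 3 has the highest number of the three, yet the comparison with compound 1 is within the scatter, a 1.1-fold higher number from compound 1 to compound 3 (0.03 log units; within the scatter), and only the step of a 2.0-fold higher number from compound 2 to compound 3 (0.31 log units; beyond the scatter) is beyond it, and that one is modest. Compound 4 (`Cc1ccc(Cl)cc1COc1ccccc1C(=O)Nc1cccnc1`) keeps the shared core and changes the ring on the saturated chain carbon bound to an oxygen on an aromatic ring: 5-chloro-2-methylphenyl in place of 2-chloro-6-fluorophenyl on a saturated chain carbon bound to an oxygen on an aromatic ring. The measured steps that bear on this are the three swaps of that ring, a 1.9-fold lower number from compound 1 to compound 2 (0.28 log units; within the scatter), a 1.1-fold higher number from compound 1 to compound 3 (0.03 log units; within the scatter) and a 2.0-fold higher number from compound 2 to compound 3 (0.31 log units; beyond the scatter); none of them moved the number far, and the whole spread across compounds 1, 2 and 3 is small. A step of similar size is therefore expected for compound 4 in this assay, most likely a slightly lower number than compound 3, as a 1.5-fold lower number from compound 3 to compound 4 (0.18 log units; within the scatter), though a result within the scatter would not be surprising. Compound 4 is estimated at 1000 nM, with a range from 400 nM to 2500 nM.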

Compound 4, half-maximal inhibitory concentration: 1100 nM
Compound 4: middle estimate off by 1.1-fold (0.04 log units), on the low side; the measured number falls inside the stated range.
By their numbers in this assay, from the lowest: compounds 2, 4, 1 and 3 (each within the scatter of the next, the first and the last beyond it).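

In this assay, the 5-chloro-2-methylphenyl ring on a saturated chain carbon bound to an oxygen on an aromatic ring brings the first methyl to this position, and the swaps from the two fluorine-bearing rings give a 1.4-fold lower number from compound 3 to compound 4 (0.13 log units; within the scatter) and a 1.5-fold higher number from compound 2 to compound 4 (0.17 log units; within the scatter), both within the scatter. Methyl in place of hydrogen on an aromatic carbon of the 3-chlorophenyl series gives a 1.3-fold lower number from compound 1 to compound 4 (0.10 log units; within the scatter) and so also leaves the number within the scatter, showing that this position accepts a methyl as well as a fluorine without a clear change. No measurement on hand offers a reason for these numbers.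

On these data alone, it remains open whether an amine or a carboxylic acid on this ring would move the number further than these swaps did. A longer chain between the oxygen and the ring also remains untested in what is shown here.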